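Fewer methoxy groups and Vero cell toxicity

This account rests on a few compounds, and the source may have more. Where it says the series, first, only, none or still open, it means among the compounds named here.

Measured compounds:
compound 1, `COc1cc(/C=C/C(=O)c2ccc(OCC(O)CNCCNc3ccnc4cc(Cl)ccc34)cc2)cc(OC)c1OC`, 1910 nM
compound 2, `O=C(/C=C/c1ccco1)NCCNc1ccnc2cc(Cl)ccc12`, 629000 nM

Both were tested in an ADME assay on Vero cells (Chlorocebus sabaeus) for cytotoxicity, read by MTT assay, with a stated time of 72 h; on this read-out lower numbers stand for higher toxicity in this test and higher numbers for lower toxicity in this test. Compound 1 gives the lowest of the two numbers; compound 2 stands far higher, beyond the scatter, so compound 1 is clearly the more toxic of the pair. Compound 3, `COc1ccc(/C=C/C(=O)c2ccc(OCC(O)CNCCNc3ccnc4cc(Cl)ccc34)cc2)cc1`, has not yet been measured. It differs from compound 1 in one place: 4-methoxyphenyl in place of 3,4,5-trimethoxyphenyl on a double-bonded chain carbon bound to a double-bonded chain carbon. Among the measured compounds shown here, no measured pair here differs in that place alone, since compound 2 differs from compound 1 in several ways at once, so the direction of the step must be guessed. Compound 3 is expected to give a somewhat higher number than compound 1, a modest step that may or may not exceed the scatter. For compound 3 the estimate in this assay is 4500 nM, likely between 1500 nM and 15000 nM. That estimate means an expected step of a 2.4-fold higher number from compound 1 to compound 3 (0.37 log units; beyond the scatter).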

Compound 3, half-maximal cytotoxic concentration: 8030 nM
Estimate against measurement, compound 3: 1.8-fold (0.25 log units) below; the range from low to high includes it.
By their numbers in this assay, from the lowest: compound 1; then compound 3; then compound 2.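

Among the compounds shown here, this is the first pair here that differs in one place only, so the change can be read by itself: in this assay putting 4-methoxyphenyl in place of 3,4,5-trimethoxyphenyl gives a 4.2-fold higher number from compound 1 to compound 3 (0.62 log units; beyond the scatter) and so lowers toxicity in this test. At this position, on a double-bonded chain carbon bound to a double-bonded chain carbon, the ring with fewer methoxy groups therefore goes with the higher number, although the step is only modest. Nothing available here explains why the number moves.

The compounds shown leave open whether any single methoxy group accounts for the step or whether all the lost groups contribute. They also leave open how an unsubstituted phenyl, a 4-hydroxyphenyl or a 4-aminophenyl ring would behave in this place.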